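The source may report more compounds than this note shows. Statements on the series, on what has been measured and on what is new or still open speak of the compounds shown alone.

Measured compounds and values in a functional assay on PC-3 cells (Homo sapiens) for inhibition, read by sulforhodamine B assay, with a stated time of 48 h; on this read-out higher numbers stand for weaker inhibition of growth and lower numbers for stronger inhibition of growth:
Compound 1 `CC1=CC[C@H](C(C)(C)NC(=S)N/N=C/c2ccccc2)CC1` gives 1300 nM.
Compound 2 `COc1ccc(/C=N/NC(=S)NC(C)(C)[C@H]2CC=C(C)CC2)cc1` gives < 40 nM, which is a limit of the assay rather than a number.
Compound 3 `CC1=CC[C@H](C(C)(C)NC(=S)N/N=C/c2ccc(O)cc2)CC1` gives 600 nM.

Among the two plain numbers in this assay, compound 3 holds the lower one; the nearest is compound 1, the step being a 2.2-fold lower number from compound 1 to compound 3 (0.34 log units; beyond the scatter). The remaining value is only a limit, (the limit of < 40 nM in this assay, at which 1 of the 3 values shown sits), so compound 3 cannot be ranked against compound 2.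

Compound 4 `CC1=CC[C@H](C(C)(C)NC(=S)N/N=C/c2cccc(Cl)c2)CC1` differs from compound 3 by 3-chlorophenyl in place of 4-hydroxyphenyl on a carbon with a double bond to nitrogen. Among the compounds with values here, no measured step swaps a hydroxy for a chlorine, so none covers this change directly. The steps that touch the departing group are a 2.2-fold lower number from compound 1 to compound 3 (0.34 log units; beyond the scatter) and an at least 15-fold higher number from compound 2 to compound 3 (1.17 log units; beyond the scatter), and the related at least 32-fold lower number from compound 1 to compound 2 (1.51 log units; beyond the scatter); together they show that what sits on this aromatic ring can move the number by a large margin in this assay, while leaving the effect of a chlorine open.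

With the hydroxy gone, compound 4 is expected to land somewhere between the unsubstituted compound 1 and compound 3, so the estimated step is a 1.2-fold higher number from compound 3 to compound 4 (0.07 log units; within the scatter). The estimate for compound 4 in this assay is 700 nM, with a range from 150 nM to 3000 nM.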

Compound 4, concentration for 50% growth inhibition: 600 nM
For compound 4 the middle estimate is 1.2-fold (0.07 log units) above the measured one; measured number inside the range.
By their numbers in this assay, from the lowest: compounds 3 and 4 (each within the scatter of the next); then compound 1. At a limit, below all of these: compound 2.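

In this assay, this place on a carbon with a double bond to nitrogen tolerates a swap of groups that share little beyond the aromatic ring: 3-chlorophenyl has no hydrogen-bond donor or acceptor, unlike 4-hydroxyphenyl, yet the result is no change at the digits printed from compound 3 to compound 4 (within the scatter). The gain over the unsubstituted phenyl ring is also of a similar kind for the chlorine as for the hydroxy, with a 2.2-fold lower number from compound 1 to compound 4 (0.34 log units; beyond the scatter), so this modest step is no longer tied to a group carrying a hydrogen-bond donor. The 4-methoxyphenyl of compound 2 remains apart from this pair, with an at least 15-fold higher number from compound 2 to compound 4 (1.17 log units; beyond the scatter), and the value of compound 2 is a limit rather than a number: the limit of < 40 nM in this assay, at which 1 of the 4 values shown sits.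

Compound 4 changes both the atom and its place on the ring, so the compounds shown cannot separate these two effects, and a 4-chlorophenyl or a 3-methoxyphenyl group would be needed to do so. As far as these compounds go, it also remains open whether the strong result of compound 2 depends on the oxygen-linked methyl itself, which a longer ethoxy chain or a dimethylamino group at the same ring place could begin to test.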